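Adding a hydroxy group to compound 1

The source may report more compounds than this note shows. Statements on the series, on what has been measured and on what is new or still open speak of the compounds shown alone.

In an ADME assay on HEK293 cells (Homo sapiens) for cytotoxicity, read by MTT assay, with a stated time of 72 h (on this read-out higher numbers stand for weaker inhibition and lower numbers for stronger inhibition), compound 1 (`COc1ccc(C2=C(c3cc(OC)c(OC)c(OC)c3)C(=O)CC2O[SiH2]C(C)(C)C)cc1`) gives > 100 ug/mL as a limit of the assay and not a number. Compound 2 (`COc1ccc(C2=C(c3cc(OC)c(OC)c(OC)c3)C(=O)C(O)C2)cc1Cl`) gives > 100 ug/mL as a limit too. Compound 3 (`COc1ccc(C2=C(c3cc(OC)c(OC)c(OC)c3)C(=O)CC2O[SiH2]C(C)(C)C)cc1O`) differs from compound 1 by hydroxy in place of hydrogen on an aromatic carbon in the change from 4-methoxyphenyl to 3-hydroxy-4-methoxyphenyl. For the measured compounds named here, no measured pair shows this change, so an at least 2.5-fold lower number from compound 1 to compound 3 (0.39 log units; beyond the scatter) is only expected, toward stronger inhibition and of uncertain size, and another result at the limit remains possible. In this assay compound 3 is estimated at 40 ug/mL with an expected range of 2 ug/mL to 120 ug/mL around that figure.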

Compound 3, half-maximal inhibitory concentration: 42 ug/mL
Estimate against measurement, compound 3: 1.1-fold (0.02 log units) below; the range from low to high includes it.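

In this assay, hydroxy in place of hydrogen on an aromatic carbon, ortho to a methoxy group, gives an at least 2.3-fold lower number from compound 1 to compound 3 (0.37 log units; beyond the scatter), so this position can respond to a change and the result is not fixed by the core of compound 1. Compound 3 is the only compound shown with a number rather than a limit: the limit of > 100 ug/mL in this assay, at which 2 of the 3 values shown sit.

The step has no upper end, since compound 1 gives only a limit. From the compounds shown here alone, whether an amine or a fluorine in this place would also give a number stays open.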